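This account rests on a few compounds, and the source may have more. Where it says the series, first, only, none or still open, it means among the compounds named here.

Compound 3 `CCC(C(=O)N1CCN(c2cccc(C)c2)CC1)N1C(=O)CCC1=O` gives 75% in a functional assay on the whole organism (strain Swiss) with Mus musculus as the target, in the maximal electroshock model, with a stated time of 1 h, at a dose of 300 mg/kg by the intraperitoneal route (a higher number here means a stronger effect of the compound at the dose given, a lower number a weaker effect), which places it second highest of the three numbers: below compound 1 `CCC(C(=O)N1CCN(c2cccc(Cl)c2)CC1)N1C(=O)CCC1=O` with 100%, reached by a number 25 percentage points lower from compound 1 to compound 3 (beyond the scatter), and above compound 2 `CCC(C(=O)N1CCN(c2ccccc2F)CC1)N1C(=O)CCC1=O` with 50%, reached by a number 25 percentage points higher from compound 2 to compound 3 (beyond the scatter). Compound 4 `CCC(C(=O)N1CCN(c2ccccc2Cl)CC1)N1C(=O)CCC1=O` differs from compound 3 by 2-chlorophenyl in place of 3-methylphenyl on an amine nitrogen in a ring. Among the measured compounds shown here, no measured step covers 2-chlorophenyl itself. The bearing steps point opposite ways: a number 50 percentage points lower from compound 1 to compound 2 (beyond the scatter) was a large fall, while a number 25 percentage points lower from compound 1 to compound 3 (beyond the scatter) was modest. Compound 4 is therefore expected to give 65%, between 30% and 100%, a step of a number 10 percentage points lower from compound 3 to compound 4 (within the scatter) that is within the scatter and may fall in either direction in this assay.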

Compound 4, a percentage reported as activity, at one dose (the size of the read-out at that dose, not a potency): 50%
Compound 4: middle estimate off by 15 percentage points, on the high side; the range from low to high includes it.
By their numbers in this assay, from the lowest: compounds 2 and 4 (each within the scatter of the next); then compound 3; then compound 1.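

In this assay chloro in place of fluoro gives no change at the digits printed from compound 2 to compound 4 (within the scatter) and so leaves the 2-halophenyl pair level. With chlorine kept, 2-chlorophenyl in place of 3-chlorophenyl gives a number 50 percentage points lower from compound 1 to compound 4 (beyond the scatter) as a large step, so the site of the chlorine on the phenyl ring matters here. Compound 4 also stands under the 3-methylphenyl compound, with a number 25 percentage points lower from compound 3 to compound 4 (beyond the scatter) as a modest step. Nothing available explains these steps. Going by these compounds, whether 2-methylphenyl, 3-fluorophenyl or unsubstituted phenyl would follow the same order remains open.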